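Shifting the halogen pattern on the benzylidene arm

This account rests on a few compounds, and the source may have more. Where it says the series, first, only, none or still open, it means among the compounds named here.

Three analogues sharing one core have been tested in a functional assay on MCF7 cells (Homo sapiens) for cytotoxicity, read by CCK-8 assay, with a stated time of 72 h; a higher number here means a weaker inhibitor, a lower number a stronger inhibitor. Compound 1 `C=CCn1c(=O)/c(=C\c2cccc(Cl)c2)[nH]c(=O)/c1=C\c1ccccc1OC` gives 5200 nM in this assay. Compound 2 `C=CCn1c(=O)/c(=C\c2ccc(Cl)c(Cl)c2)[nH]c(=O)/c1=C\c1ccccc1OC` is reported in this assay as "not active" (no number reported). Compound 3 `C=CCn1c(=O)/c(=C\c2ccc(F)c(Br)c2)[nH]c(=O)/c1=C\c1ccccc1OC` is likewise reported in this assay as "not active" (no number reported), so no number stands for it, and it sits together with compound 2 among the entries without a value, while compound 1 alone carries a measured concentration.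

Compound 4 `C=CCn1c(=O)/c(=C\c2cc(F)ccc2C)[nH]c(=O)/c1=C\c1ccccc1OC` is not yet measured. It differs from compound 3 in one place: 5-fluoro-2-methylphenyl in place of 3-bromo-4-fluorophenyl on a double-bonded chain carbon bound to an aromatic carbon. The change keeps the count of heavy atoms and of donors and acceptors, and only the substitution pattern of the aryl ring on that chain carbon is altered.

For the measured compounds named here, no measured step between two compounds exists here, so the size of the move in this assay can only be guessed. Because compound 3 is recorded as "not active" (no number reported), and because compound 1 gives only 5200 nM, nothing in the data points toward strong inhibition for this series. Compound 4 is therefore expected to be weak, with an estimated value of 12000 nM, in a range from 3000 nM to 50000 nM, and a real chance that it too is returned without a number.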

Compound 4, half-maximal inhibitory concentration: 3100 nM
The estimate for compound 4 lay 3.9-fold (0.59 log units) above the measured number; the range from low to high includes it.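

Swapping the aryl group on a double-bonded chain carbon bound to an aromatic carbon separates compound 3, recorded in this assay as "not active" (no number reported), from compound 4 at 3100 nM in the same assay, so in this pair the change from 3-bromo-4-fluorophenyl to 5-fluoro-2-methylphenyl marks the difference between an entry without a number and a measured one. For the compounds shown here, the one step that can be read is a 1.7-fold lower number from compound 1 to compound 4 (0.22 log units; within the scatter) and it shows that 3-chlorophenyl and 5-fluoro-2-methylphenyl cannot be told apart in this assay, while steps involving the entries without a number cannot be read. No experimental evidence is available to explain why compound 3 and compound 4 are recorded differently.

The compounds shown leave open whether the methyl group, the fluorine or the arrangement of the two on the ring accounts for the measured value of compound 4. They also leave open how this series would respond to an amine or a carboxylic acid on the same aryl ring, or to a change in the 2-methoxyphenyl group on the other arm.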